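The source may report more compounds than this note shows. Statements on the series, on what has been measured and on what is new or still open speak of the compounds shown alone.

Of the compounds shown here, three sharing one core have been tested in an ADME assay on Vero cells (Chlorocebus sabaeus) for cytotoxicity, read by MTT assay, with a stated time of 72 h; on this read-out lower numbers stand for higher toxicity in this test and higher numbers for lower toxicity in this test: compound 1 `N/C(=N/NC(CC(=O)c1ccc(-n2ccnc2)cc1)c1ccc(F)cc1)c1ccccn1` gives 78800 nM, compound 2 `N/C(=N/NC(CC(=O)c1ccc(-n2ccnc2)cc1)c1ccccc1[N+](=O)[O-])c1ccccn1` gives 48000 nM and compound 3 `N/C(=N/NC(CC(=O)c1ccc(-n2ccnc2)cc1)c1cccc(F)c1)c1ccccn1` gives 26500 nM. Two steps fix the standing of compound 3: a 3.0-fold lower number from compound 1 to compound 3 (0.47 log units; beyond the scatter), and a 1.8-fold lower number from compound 2 to compound 3 (0.26 log units; within the scatter). Compound 4 `N/C(=N/NC(CC(=O)c1ccc(-n2ccnc2)cc1)c1cccc([N+](=O)[O-])c1)c1ccccn1` changes one group: nitro in place of fluoro on an aromatic carbon. Going by the values given here, no measured step makes this exact swap. The closest guide is the 2-nitrophenyl group of compound 2, since a 1.6-fold lower number from compound 1 to compound 2 (0.22 log units; within the scatter) and the step to the 3-fluorophenyl group both stayed small. No step beyond the scatter is therefore expected in this assay. The estimated step is a 1.4-fold higher number from compound 3 to compound 4 (0.13 log units; within the scatter). For compound 4 the expected value is 36000 nM, with an estimated range of 14000 nM to 90000 nM.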

Compound 4, half-maximal cytotoxic concentration: 28700 nM
Compound 4: middle estimate off by 1.3-fold (0.10 log units), on the high side; measured number inside the range.
By their numbers in this assay, from the lowest: compounds 3, 4, 2 and 1 (each within the scatter of the next, the first and the last beyond it).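

On this aromatic carbon, a nitro group with its three heavy atoms reads much like a single fluoro in this assay, with a 1.1-fold higher number from compound 3 to compound 4 (0.03 log units; within the scatter) as the result of the swap. Moving the nitro from the 2-nitrophenyl to the 3-nitrophenyl arrangement gives a 1.7-fold lower number from compound 2 to compound 4 (0.22 log units; within the scatter) and so cannot be told apart, whereas replacing 4-fluorophenyl with 3-nitrophenyl gives a 2.7-fold lower number from compound 1 to compound 4 (0.44 log units; beyond the scatter) and is a modest but real step. No supporting data here explain these results. From the compounds shown here alone, whether an amine or a carboxylic acid on the same carbon would shift the number stays open, as does how 4-nitrophenyl would compare with the 4-fluorophenyl of compound 1.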